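A few compounds are considered here, and "the series" means these few. Any claim that something is new, unique, unknown or untested is made for them only; others in the source may bear on it.

Among the three measured compounds, compound 3 `O=[N+]([O-])c1ccc(-c2cc(-c3ccccc3-c3ccccc3)n[nH]2)cc1` gives the lowest number in a functional assay on NCI-H460 cells (Homo sapiens) for inhibition, read by MTT assay, with a stated time of 48 h (a higher number here means a weaker inhibitor of growth, a lower number a stronger inhibitor of growth), namely 2700 nM. Compound 1 `COc1ccccc1-c1cc(-c2ccccc2-c2ccccc2)n[nH]1` gives 9100 nM and compound 2 `COc1cccc(-c2cc(-c3ccccc3-c3ccccc3)n[nH]2)c1` gives 8700 nM; both numbers lie beyond the scatter above that of compound 3. Among the measured compounds shown here, the one measured step, a 1.0-fold lower number from compound 1 to compound 2 (0.02 log units; within the scatter), concerns 3-methoxyphenyl in place of 2-methoxyphenyl and is within the scatter, so it says nothing about the change now considered.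

Compound 4 `Nc1ccc(-c2cc(-c3ccccc3-c3ccccc3)n[nH]2)cc1` differs from compound 3 by amino in place of nitro on an aromatic carbon. For the measured compounds named here, no measured step in this set exchanges a nitro for an amino group, so the direction and size of the change cannot be read from a precedent. Since compound 3 stands alone at the low end, and the two other compounds sit some way above it, the estimate for compound 4 is placed between those values, with a wide range, as a 1.9-fold higher number from compound 3 to compound 4 (0.27 log units; within the scatter). Compound 4 is therefore expected to give about 5000 nM in this assay, estimated to fall between 1500 nM and 15000 nM.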

Compound 4, concentration for 50% growth inhibition: 8200 nM
Compound 4: middle estimate off by 1.6-fold (0.21 log units), on the low side; low and high end bracket the measured number.
By their numbers in this assay, from the lowest: compound 3; then compounds 4, 2 and 1 (each within the scatter of the next).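

In this assay, among the compounds shown here, amino in place of nitro para to a large group gives a 3.0-fold higher number from compound 3 to compound 4 (0.48 log units; beyond the scatter) and is the first step at this position that lies beyond the scatter, so the lower number of compound 3 does not carry over to the amino compound. The other two new steps, a 1.1-fold lower number from compound 2 to compound 4 (0.03 log units; within the scatter) and a 1.1-fold lower number from compound 1 to compound 4 (0.05 log units; within the scatter), both lie within the scatter, which leaves compound 3 as the only one of the four set apart. Nothing at hand bears on why nitro and amino differ at this place.

On these data alone, it remains open whether other groups at this place, such as a nitrile, a carboxylic acid or a methyl ester, would match nitro or amino. As far as these compounds go, it also remains open whether the nitro group would keep its lower number elsewhere on this ring.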